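The source may report more compounds than this note shows. Statements on the series, on what has been measured and on what is new or still open speak of the compounds shown alone.

Of the compounds shown here, three of a shared core have been measured in a functional assay on U-87MG ATCC cells (Homo sapiens) for inhibition, read by MTT assay, with a stated time of 72 h; a higher number here means a weaker inhibitor, a lower number a stronger inhibitor. Compound 1 `COc1cc2c(Oc3ccc(NC(=O)c4nn(-c5ccccc5C(F)(F)F)c(=O)cc4C)cc3F)ccnc2cc1OCCCN1CCC(C)CC1` gives 1120 nM. For the measured compounds named here, compound 2 `COc1cc2c(Oc3ccc(NC(=O)c4nn(-c5ccccc5OC(F)(F)F)c(=O)cc4C)cc3F)ccnc2cc1OCCCN1CCC(C)CC1` gives 800 nM; the one step measured so far, a 1.4-fold lower number from compound 1 to compound 2 (0.15 log units; within the scatter), shows no change beyond the scatter. Compound 3 `COc1cc2c(Oc3ccc(NC(=O)c4nn(-c5cccc(F)c5)c(=O)cc4C)cc3F)ccnc2cc1OCCCN1CCCCC1` gives 1500 nM, the highest of the three numbers, but its distance to compound 1 and to compound 2 lies within the scatter, so the three cannot be ranked.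

Compound 4 `COc1cc2c(Oc3ccc(NC(=O)c4nn(-c5cccc(F)c5)c(=O)cc4C)cc3F)ccnc2cc1OCCCN1CCC(C)CC1` differs from compound 3 in one place: methyl in place of hydrogen on a saturated ring carbon. Going by the values given here, no measured step covers this change directly. Among the compounds with values here, the only comparison touching it is indirect: compound 1 carries the methylated ring and compound 3 the bare one, yet they also differ elsewhere, and their two values sit within the scatter of one another. On that basis the step of a 1.3-fold lower number from compound 3 to compound 4 (0.10 log units; within the scatter) is expected to be small, with no direction claimed beyond the scatter. Compound 4 is therefore estimated at 1200 nM, with a likely range from 550 nM to 2600 nM.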

Compound 4, half-maximal inhibitory concentration: 1800 nM
The estimate for compound 4 lay 1.5-fold (0.18 log units) below the measured number; the measured number falls inside the stated range.
By their numbers in this assay, from the lowest: compounds 2, 1, 3 and 4 (each within the scatter of the next, the first and the last beyond it).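

For the compounds shown here, with the group on the aromatic nitrogen held fixed, a 1.2-fold higher number from compound 3 to compound 4 (0.08 log units; within the scatter) gives the first direct reading of this saturated ring carbon: in this assay, methyl in place of hydrogen makes no difference beyond the scatter. Compound 4 also shares the 4-methylpiperidin-1-yl group with two earlier compounds, so 3-fluorophenyl can now be compared on its own with two other groups on the aromatic nitrogen: a 1.6-fold higher number from compound 1 to compound 4 (0.21 log units; within the scatter) stays within the scatter, while a 2.3-fold higher number from compound 2 to compound 4 (0.35 log units; beyond the scatter) is a modest step beyond it. No measurement at hand explains these results.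

Still open, on these data alone, is whether a group other than methyl on this ring carbon, such as ethyl, hydroxyl or dimethylamino, would shift the number beyond the scatter. Also open, as far as these compounds go, is whether the step between 2-(trifluoromethoxy)phenyl and 3-fluorophenyl would persist with piperidin-1-yl in place of 4-methylpiperidin-1-yl.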